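The source may report more compounds than this note shows. Statements on the series, on what has been measured and on what is new or still open speak of the compounds shown alone.

Measured so far:
- compound 1, `CCCCCCCNc1cnc(C(=O)NCc2ccccc2)cn1`, in an ADME assay on HEL cells (Homo sapiens) for cytotoxicity, read by microscopy, with a stated time of 6 days; a higher number here means that more compound is tolerated, a lower number that less compound is tolerated: > 100000 nM
- compound 2, `CCCCCCCCNc1nccnc1C(=O)NCc1ccccc1`, in this assay: > 100000 nM

The two compounds share a core with a long saturated chain on a ring nitrogen and a benzyl amide; they differ only in the arrangement around the core and in the length of the chain. For compound 1 the value > 100000 nM is a limit of this assay, not a number. For compound 2 the value > 100000 nM is likewise a limit and not a number. Compound 2 therefore stands at the edge of what this assay can report, because of the limit of > 100000 nM in this assay, at which 2 of the 2 values shown sit.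

Compound 3, `CCCCCCCNc1nccnc1C(=O)NCc1ccccc1`, is not yet measured. Its difference from compound 2 is hydrogen in place of methyl on a saturated chain carbon, seven bonds along the chain from a nitrogen on an aromatic ring.

Going by the values given here, no step between measured compounds is available to show how such a change moves this read-out. A shortening of the chain by one carbon is a small change, and the estimated step that the limit leaves unreadable from compound 2 to compound 3 is expected to stay within the scatter, with no change in direction. Compound 3 is therefore estimated at 150000 nM, between 50000 nM and 500000 nM, most likely again reported only as a limit.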

Compound 3, minimum cytotoxic concentration: 100000 nM
Compound 3: the middle estimate sits 1.5-fold (0.18 log units) above what was measured; low and high end bracket the measured number.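

In this assay, going by these compounds alone, placing hydrogen where methyl stood on a saturated chain carbon, seven bonds along the chain from a nitrogen on an aromatic ring, gives a number no higher from compound 2 to compound 3 (the limit leaves the size open), which is the first hint of a direction for this change at this position, though only a loose one. Compound 3, at 100000 nM, also gives the first actual number among the compounds shown rather than a limit, so this chain now has a fixed reference point for later comparisons. The size of the step cannot be read, because compound 2 sits at a limit of the assay and not at a number: the limit of > 100000 nM in this assay, at which 2 of the 3 values shown sit.

The compounds shown leave open how the read-out would respond to a longer chain, or to a much shorter one such as ethyl, and whether any chain length would bring a clear shift. On these data alone, they also leave open what an amine or a carboxylic acid in place of this methyl would do, so it remains unknown whether the read-out depends on the chain's length alone or also on what the chain carries.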